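The source may hold more compounds than are shown below. What is called first, only, known or untested is meant among the compounds shown, and "the series" means these compounds.

Working notes on the series. The shared core is that of compound 1 `COc1cc(OC)c2c(-n3ccnc3)cc(-c3ccccc3)nc2c1`. In a functional assay on A549 cells (Homo sapiens) for inhibition, read by MTT assay, with a stated time of 72 h (a higher number here means a weaker inhibitor, a lower number a stronger inhibitor), compound 1 gives only a limit, > 100000 nM. Compound 2 `COc1cc(OC)c2c(N3CCCCC3)cc(-c3ccccc3)nc2c1` likewise gives only a limit in this assay, > 100000 nM. The step that the two limits leave unreadable from compound 1 to compound 2 is thus unreadable, as the limit of > 100000 nM in this assay, at which 2 of the 2 values shown sit, shows. Compound 2 therefore stands at that limit, with no number beyond it. Compound 3 `COc1cc(OC)c2c(NC3CCCCC3)cc(-c3ccccc3)nc2c1` differs by cyclohexylamino in place of piperidin-1-yl on an aromatic carbon. Going by the values given here, the one measured step bears on this change without a readable size, so no step beyond the scatter is expected in this assay. For compound 3 the expected value is 150000 nM, within 40000 nM to 600000 nM. That estimate implies a step that the limit leaves unreadable from compound 2 to compound 3.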

Compound 3, half-maximal inhibitory concentration: 6590 nM
Compound 3: middle estimate off by 23-fold (1.36 log units), on the high side; the measured number lies below the stated range.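

Changing the group at this position does move the read-out in this assay, which the earlier pair could not show: cyclohexylamino gives an at least 15-fold lower number from compound 2 to compound 3 (1.18 log units; beyond the scatter), and against 1H-imidazol-1-yl it gives an at least 15-fold lower number from compound 1 to compound 3 (1.18 log units; beyond the scatter). Both steps are bounded on one side only, and their full size stays unknown: the limit of > 100000 nM in this assay, at which 2 of the 3 values shown sit.

The change from piperidin-1-yl adds a hydrogen-bond donor and alters the ring, and the compounds shown do not separate these two differences. On these data alone, an N-methylcyclohexylamino group or a plain amino group at this position remains open.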